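The compounds below may be only part of what the source reports. "The series", "measured", "known", "first", "only" and "open" are said of these compounds alone.

Four compounds share one core and differ in two places. Compound 1 `COc1ccc(N(CC(=O)NCCCSc2ccccc2)C(=O)/C=C/c2ccccc2)cc1` carries a 2-phenylethenyl group on a carbonyl carbon and a phenylsulfanyl group on the chain, compound 2 `COc1ccc(N(CC(=O)NCCCSc2ccccc2)C(=O)c2ccccc2)cc1` has a phenyl group on that carbonyl carbon with the same phenylsulfanyl group, compound 3 `COc1ccc(N(CC(=O)NCCC[Te]c2ccccc2)C(=O)c2ccccc2)cc1` keeps the phenyl but has tellurium in the chain in place of sulfur, and compound 4 `COc1ccc(N(CC(=O)NCCC[Te]c2ccccc2)C(=O)/C=C/c2ccccc2)cc1`, not yet measured, joins the 2-phenylethenyl group to the tellurium-bearing chain.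

In a functional assay on A-431 cells (Homo sapiens) for cytotoxicity, read by MTT assay, with a stated time of 24 h (a lower number here means a stronger inhibitor, a higher number a weaker inhibitor), compound 1 reaches the limit of the assay, >= 100000 nM, not a number. Compound 2 likewise gives the limit >= 100000 nM. Among the measured compounds shown here, compound 3 gives 5000 nM, the only true number here. The change from compound 2 to compound 3 is a group of 7 heavy atoms (6 carbon, 1 tellurium; one six-membered aromatic ring of carbon only) in place of a group of 7 heavy atoms (6 carbon, 1 sulfur; one six-membered aromatic ring of carbon only), on a saturated chain carbon, three bonds along the chain from an amide-type nitrogen, and the step is an at least 20-fold lower number from compound 2 to compound 3 (1.30 log units; beyond the scatter). The change from compound 2 to compound 1 is 2-phenylethenyl in place of phenyl on a carbonyl carbon, and the step is a step that the two limits leave unreadable from compound 2 to compound 1 because both sit at the limit of >= 100000 nM in this assay, at which 2 of the 3 values shown sit.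

The same change, (2-phenylethenyl in place of phenyl on a carbonyl carbon), is made from compound 3 to compound 4. The step from compound 3 to compound 4 is expected to be a 1.4-fold higher number from compound 3 to compound 4 (0.15 log units; within the scatter), a guess with a wide band. Compound 4 is estimated at 7000 nM, within 1500 nM to 40000 nM.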

Compound 4, half-maximal inhibitory concentration: 6000 nM
Compound 4: middle estimate off by 1.2-fold (0.07 log units), on the high side; the range from low to high includes it.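

In this assay, tellurium in place of sulfur in the chain gives an at least 16-fold lower number from compound 1 to compound 4 (1.22 log units; beyond the scatter), so the change points the same way with either group on the carbonyl carbon. The two cores agree in direction, but the true sizes of the steps cannot be compared, since each step starts from a limit rather than a number: the same change on two cores in this assay, an at least 20-fold lower number (1.30 log units; beyond the scatter) from compound 2 to compound 3 and an at least 16-fold lower number (1.22 log units; beyond the scatter) from compound 1 to compound 4; the limit leaves it open whether they differ The other change, 2-phenylethenyl in place of phenyl, can be read only among the tellurium compounds, as a 1.2-fold higher number from compound 3 to compound 4 (0.08 log units; within the scatter), while the same step between the sulfur compounds cannot be read: the limit of >= 100000 nM in this assay, at which 2 of the 4 values shown sit.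

These compounds leave open whether selenium in the chain would give a number nearer to that of the tellurium compounds or to the limit of the sulfur compounds. They also leave open whether the tellurium step would hold with a longer chain or with an amine on the aromatic ring of the shared core.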